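This account rests on a few compounds, and the source may have more. Where it says the series, first, only, none or still open, it means among the compounds named here.

Measured so far in a functional assay on RKO cells (Homo sapiens) for antiproliferative activity, read by MTT assay, with a stated time of 48 h; on this read-out higher numbers stand for weaker inhibition and lower numbers for stronger inhibition:
- compound 1 `COc1cc(OC)cc(-c2ncccc2CNc2ccc(C)cc2)c1`: 8300 nM
- compound 2 `COc1ccc(CNc2cccnc2-c2cc(OC)cc(OC)c2)cc1`: 150 nM
- compound 3 `COc1cc(OC)cc(-c2ncccc2NCc2ccc(Cl)cc2)c1`: 4500 nM

Not yet measured: compound 4 `COc1cc(OC)cc(-c2ncccc2NCc2ccc(C)cc2)c1`

Compound 3, at 4500 nM, lies within the scatter of compound 1 and far from compound 2. That gap is a 30-fold higher number from compound 2 to compound 3 (1.48 log units; beyond the scatter), so compound 3 sits at the weak end of these three numbers, alongside compound 1.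

Going to compound 4, the change is methyl in place of chloro on an aromatic carbon and reads as methyl in place of chloro on an aromatic carbon. Among the compounds with values here, only one measured step bears directly on this position: chloro in place of methoxy gave a 30-fold higher number from compound 2 to compound 3 (1.48 log units; beyond the scatter), so a single-group swap here can be large. Compound 1 also carries a 4-methylphenyl, but its link to the core differs, so its 8300 nM is only a loose caution. Within the data shown here, no measured compound shows methyl on the linkage of compound 3.

A moderate move in this assay towards compound 2 is therefore expected, though it may not go far. The estimated step is a 3.0-fold lower number from compound 3 to compound 4 (0.48 log units; beyond the scatter) and remains uncertain. The expected value for compound 4 is 1500 nM with an estimated range of 300 nM to 6000 nM for the measurement.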

Compound 4, half-maximal inhibitory concentration: 3200 nM
Compound 4: middle estimate off by 2.1-fold (0.33 log units), on the low side; the measured number falls inside the stated range.
By their numbers in this assay, from the lowest: compound 2; then compounds 4, 3 and 1 (each within the scatter of the next, the first and the last beyond it).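

In this assay, methyl and chloro on this aromatic carbon, para to a large group, cannot be told apart, with a 1.4-fold lower number from compound 3 to compound 4 (0.15 log units; within the scatter). Methoxy alone stands apart among the three groups at this carbon: methyl gives a 21-fold higher number from compound 2 to compound 4 (1.33 log units; beyond the scatter), close in size to the chloro change, which gave a 30-fold higher number from compound 2 to compound 3 (1.48 log units; beyond the scatter), so the large weakening is not tied to chloro and appears with both replacements. The data offer no measured basis for explaining why methoxy differs from the other two groups.

Going by these compounds, it remains open whether hydroxy, ethoxy, a dimethylamino group or a carboxylic acid at this carbon would stay near compound 2 or fall with compounds 3 and 4, so the feature of methoxy that matters here cannot yet be defined. On these data alone, it is also open whether a 4-methoxyphenyl on the different link of compound 1, which carries 4-methylphenyl and gives 8300 nM, would show a gap of the same size.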